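The source may hold more compounds than are shown below. What is called first, only, known or untested is meant among the compounds shown, and "the series" means these compounds.

Compound 1 `Cc1cc(C(=O)NC(C)(C)C)nn1Cc1cc(Cl)cc2cc(-c3ccccc3)oc12` gives 10 nM in an assay on CHO-K1 cells for displacement of a labelled ligand from prostaglandin E2 receptor EP1 subtype (Homo sapiens), read by scintillation counting, with a stated time of 45 min; on this read-out higher numbers stand for weaker inhibition and lower numbers for stronger inhibition. Compound 2 `Cc1cc(C(=O)NCC2CCNCC2)nn1Cc1cc(Cl)cc2cc(-c3ccccc3)oc12` gives 20 nM in this assay.

Compound 2 holds the higher of the two numbers, yet the step of a 2.0-fold higher number from compound 1 to compound 2 (0.30 log units; within the scatter) stays within the scatter, so no order between the two can be claimed. Compound 3 `Cc1cc(NC(=O)CC2CCNCC2)nn1Cc1cc(Cl)cc2cc(-c3ccccc3)oc12` keeps every atom of compound 2 but joins them differently: (((piperidin-4-yl)methyl)carbonyl)amino in place of ((piperidin-4-yl)methyl)carbamoyl on an aromatic carbon. Among the compounds with values here, no measured step touches a change of this kind; the single known step concerns only the group on the amide-type nitrogen. Compound 3 is therefore expected close to compound 2, with a widened range, at 40 nM between 10 nM and 160 nM, a step of a 2.0-fold higher number from compound 2 to compound 3 (0.30 log units; within the scatter).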

Compound 3, half-maximal inhibitory concentration: 63.1 nM
Compound 3: middle estimate off by 1.6-fold (0.20 log units), on the low side; the measured number falls inside the stated range.
By their numbers in this assay, from the lowest: compounds 1 and 2 (each within the scatter of the next); then compound 3.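

Joining the same atoms the other way round on this aromatic carbon gives the first step beyond the scatter in this assay, with a 3.2-fold higher number from compound 2 to compound 3 (0.50 log units; beyond the scatter) as the result. The comparison with the tert-butyl amide gives a 6.3-fold higher number from compound 1 to compound 3 (0.80 log units; beyond the scatter) and is also beyond the scatter. So the direction of the amide link at this position registers in the read-out, whereas the group on the amide-type nitrogen alone stayed within the scatter. Nothing available explains this difference. Still open, from the compounds shown here alone, is how a carboxylic acid or a plain amine on this aromatic carbon would read.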